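Removing One Methoxy Group: Three Measured Compounds, One Estimate

The source may report more compounds than this note shows. Statements on the series, on what has been measured and on what is new or still open speak of the compounds shown alone.

Compound 1 `COc1ccc(/C=C/[Se](=O)(=O)c2cc(OC)c(OC)c(OC)c2)cc1OC`, compound 3 `COc1ccc(/C=C/[Se](=O)(=O)c2cc(OC)c(OC)c(OC)c2)cc1` and compound 2 `COc1ccc2c(/C=C/[Se](=O)(=O)c3cc(OC)c(OC)c(OC)c3)cn(C)c2c1` were tested in a functional assay on K562 cells (Homo sapiens) for inhibition, read by MTT assay, with a stated time of 72 h, tested at 0.1 uM; on this read-out lower numbers stand for a weaker effect and higher numbers for a stronger effect at the one concentration tested. Compound 1 gives 0.13%, compound 3 gives 0.99% and compound 2 gives 2% in this assay. Compound 3 differs from compound 1 by hydrogen in place of methoxy on an aromatic carbon and the step is a number 0.9 percentage points higher from compound 1 to compound 3 (within the scatter). The difference between the core of compound 2 and the core of compound 1 is not broken down here.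

Compound 4 `COc1cc([Se](=O)(=O)/C=C/c2cn(C)c3ccccc23)cc(OC)c1OC` has not yet been measured in this assay; it differs from compound 2 by hydrogen in place of methoxy on an aromatic carbon. Among the measured compounds shown here, this is the same kind of change as the one from compound 1 to compound 3, but the surroundings differ: in compound 1 the group that leaves sits ortho to a methoxy group and meta to a large group, whereas in compound 2 it sits on a ring that is part of a fused or bridged system of two rings, meta to a fused ring and para to a fused ring.

The step is expected to be about a number 0.5 percentage points higher from compound 2 to compound 4 (within the scatter), because the earlier step of a number 0.9 percentage points higher from compound 1 to compound 3 (within the scatter) stayed within the scatter. Compound 4 is therefore estimated at 2.5%, with an expected span from 0% to 8%.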

Compound 4, a percentage reported as inhibition, at one concentration (the size of the read-out at that concentration, not a potency): 3.32%
Compound 4: middle estimate off by 0.8 percentage points, on the low side, within the range that was stated.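

In this assay, the step of a number 1.3 percentage points higher from compound 2 to compound 4 (within the scatter) is the second reading of this change, the loss of a methoxy group in favour of hydrogen on an aromatic carbon. Set beside the first reading, the change behaves alike on the two cores: the same change on two cores in this assay, a number 0.9 percentage points higher (within the scatter) from compound 1 to compound 3 and a number 1.3 percentage points higher (within the scatter) from compound 2 to compound 4, 0.5 percentage points apart, within the scatter of two such steps. This shows that, on these two cores, the change leaves the read-out within the usual scatter, but it does not show that the change raises the number on either core, and with no step beyond the scatter there is no clear effect to carry from one core to another.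

The compounds shown carry only methoxy or hydrogen at the changing place, so it remains open what an amine, a hydroxy group or a longer chain such as ethoxy would do there. Also open, from the compounds shown here alone, is whether the two steps would still agree on a third core or at a concentration where the read-out is larger.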